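The source may hold more compounds than are shown below. What is called first, only, known or untested is meant among the compounds shown, and "the series" means these compounds.

Measured compounds:
Compound 1 `O=C(/C=C/c1ccc(I)cc1)c1ccc(OCB(O)O)cc1`: 100000 nM
Compound 2 `O=C(/C=C/c1ccc(F)c(Br)c1)c1ccc(B(O)O)cc1`: 38000 nM
Compound 3 `O=C(/C=C/c1ccccc1)c1ccc[nH]1`: 38000 nM

In a functional assay on MCF-12A cells (Homo sapiens) for inhibition (on this read-out lower numbers stand for stronger inhibition and higher numbers for weaker inhibition), compound 2 gives 38000 nM, which is level at the digits shown with compound 3, and these two are together the lowest of the three numbers. Compound 1 gives a higher number than compound 2, a gap beyond the scatter.

Compound 4 `O=C(/C=C/c1ccc(F)c(Cl)c1)c1ccc(B(O)O)cc1` has not yet been measured in this assay. It differs from compound 2 by chloro in place of bromo on an aromatic carbon. Among the measured compounds shown here, no step between two measured compounds covers such an exchange, so the data give no direct guide to its size. The step of a 1.2-fold higher number from compound 2 to compound 4 (0.07 log units; within the scatter) is expected to stay within the scatter, or at most to weaken inhibition slightly. Compound 4 is therefore estimated at 45000 nM, with a range from 15000 nM to 130000 nM.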

Compound 4, half-maximal inhibitory concentration: 22000 nM
The estimate for compound 4 lay 2.0-fold (0.31 log units) above the measured number, within the range that was stated.
By their numbers in this assay, from the lowest: compounds 4, 2 and 3 (each within the scatter of the next); then compound 1.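

In this assay, chloro in place of bromo on an aromatic carbon, ortho to a fluoro group, gives a 1.7-fold lower number from compound 2 to compound 4 (0.24 log units; within the scatter), so the two halogens cannot be told apart at this position. Among the compounds shown here, this is the first step that isolates a single change, and the earlier compounds could not show this. Nothing at hand offers a reason for the result. What the compounds shown leave open is whether an amine, a methoxy group or a nitrile at this position would also stay within the scatter. From the compounds shown here alone, it also remains open whether this exchange would give the same result on a different core.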